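Changing the ring at the end of the triple bond

The source may report more compounds than this note shows. Statements on the series, on what has been measured and on what is new or still open speak of the compounds shown alone.

Compound 1 `CNC(=O)[C@@]12C[C@@H]1[C@@H](n1cnc3c(NC)nc(C#Cc4ccc(OC)cc4)nc31)[C@H](O)[C@@H]2O`: 0.63 nM
Compound 2 `CNC(=O)[C@@]12C[C@@H]1[C@@H](n1cnc3c(NC)nc(C#Cc4cccc(C(F)(F)F)c4)nc31)[C@H](O)[C@@H]2O`: 3.39 nM

Both compounds were tested in an assay on CHO cells for displacement of a labelled ligand from adenosine receptor A3 (Homo sapiens), read by scintillation counting, with a stated time of 60 min; on this read-out higher numbers stand for weaker inhibition and lower numbers for stronger inhibition. Among the compounds with values here, compound 2 gives the higher of the two numbers, and its only neighbour is compound 1: the step of a 5.4-fold higher number from compound 1 to compound 2 (0.73 log units; beyond the scatter) lies beyond the scatter and is modest in size. Compound 3 `CNC(=O)[C@@]12C[C@@H]1[C@@H](n1cnc3c(NC)nc(C#Cc4cccnc4)nc31)[C@H](O)[C@@H]2O` has not yet been measured. It differs from compound 2 in one place: pyridin-3-yl in place of 3-(trifluoromethyl)phenyl on a triple-bonded carbon. Within the data shown here, no measured compound carries a pyridin-3-yl group, so the only step that bears on this change is the one from compound 1 to compound 2, which shows that swapping the ring on the triple-bonded carbon shifts the number by a modest amount. A step of comparable size, or none beyond the scatter, is therefore expected in this assay. The expected step is a 1.7-fold lower number from compound 2 to compound 3 (0.23 log units; within the scatter). Compound 3 is estimated at 2 nM, with a range from 0.5 nM to 8 nM.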

Compound 3, inhibition constant: 2.15 nM
Beside the measured number, compound 3's estimate is 1.1-fold (0.03 log units) below it; low and high end bracket the measured number.
By their numbers in this assay, from the lowest: compound 1; then compounds 3 and 2 (each within the scatter of the next).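

In this assay, pyridin-3-yl in place of 3-(trifluoromethyl)phenyl on a triple-bonded carbon gives a 1.6-fold lower number from compound 2 to compound 3 (0.20 log units; within the scatter), so a ring of 6 heavy atoms with a hydrogen-bond acceptor cannot be told apart here from a group of 10 heavy atoms with none. The same pyridin-3-yl in place of 4-methoxyphenyl gives a 3.4-fold higher number from compound 1 to compound 3 (0.53 log units; beyond the scatter), which leaves compound 1 with the lowest number of the three, its steps to both others lying beyond the scatter. Nothing available explains these differences.

The compounds shown leave open how this position would respond to a ring carrying an amine or a carboxylic acid. They also leave open whether the ring is needed at all, since a plain alkyl chain on the triple-bonded carbon is not among them.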